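This account rests on a few compounds, and the source may have more. Where it says the series, first, only, none or still open, it means among the compounds named here.

Measured compounds in a functional assay on the whole organism for inhibition, with Rattus norvegicus as the target, read by paw edema, with stated times of 30 min and 4 h, at a dose of 10 mg/kg by the oral route; a lower number here means less inhibition, a higher number more inhibition at the dose given (going by the name of the read-out):
compound 1, `O=C1N=C(C2C(=O)c3ccccc3C2=O)CC(c2ccccc2[N+](=O)[O-])N1`: 32%
compound 2, `COc1ccc(C2CC(C3C(=O)c4ccccc4C3=O)=NC(=O)N2)cc1`: 10%
compound 3, `O=C1N=C(C2C(=O)c3ccccc3C2=O)CC(c2cccc([N+](=O)[O-])c2)N1`: 12%

Compound 3 gives the second highest of these three numbers; its nearest neighbour is compound 2, a number 2 percentage points higher from compound 2 to compound 3 (within the scatter), and its furthest is compound 1, a number 20 percentage points lower from compound 1 to compound 3 (beyond the scatter). Compound 4, `O=C1N=C(C2C(=O)c3ccccc3C2=O)CC(c2ccc([N+](=O)[O-])cc2)N1`, has not yet been measured. It differs from compound 3 in one place: 4-nitrophenyl in place of 3-nitrophenyl on a saturated ring carbon.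

Going by the values given here, two measured steps bear on changing the group on this saturated ring carbon. a number 20 percentage points lower from compound 1 to compound 3 (beyond the scatter) and a number 22 percentage points lower from compound 1 to compound 2 (beyond the scatter) show that moving away from 2-nitrophenyl costs inhibition, while a number 2 percentage points higher from compound 2 to compound 3 (within the scatter) shows that 3-nitrophenyl and 4-methoxyphenyl sit within the scatter of each other. Among the compounds with values here, no measured step covers a 4-nitrophenyl group, so the expectation rests on these neighbours only. Compound 4 is therefore expected to stay near compound 3, with a number 1 percentage points higher from compound 3 to compound 4 (within the scatter) expected to fall within the scatter. The estimate for compound 4 is 13%, ranging from 3% to 25%.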

Compound 4, a percentage reported as inhibition, in the whole organism at one dose (the size of the read-out at that dose, not a potency): 18%
Estimate against measurement, compound 4: 5 percentage points below, within the range that was stated.
By their numbers in this assay, from the lowest: compounds 2, 3 and 4 (each within the scatter of the next); then compound 1.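

In this assay the swap to 4-nitrophenyl from 3-nitrophenyl on this saturated ring carbon gives a number 6 percentage points higher from compound 3 to compound 4 (within the scatter) and the swap of methoxy for nitro on the aromatic carbon gives a number 8 percentage points higher from compound 2 to compound 4 (within the scatter) so compound 2, compound 3 and compound 4 cannot be told apart here. Going by these compounds alone, the comparison with the 2-nitrophenyl group gives a number 14 percentage points lower from compound 1 to compound 4 (beyond the scatter) and this means that, of the three nitrophenyl isomers, only the one in compound 1 stands apart, while having a nitro group on the phenyl ring is not enough on its own to match compound 1. Nothing measured here gives a reason why the 2-nitrophenyl group stands apart.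

On these data alone, it remains open whether the nitro group itself matters, which a 2-aminophenyl or 2-methoxyphenyl group on the same carbon could test. As far as these compounds go, it is also open how a carboxylic acid on the phenyl ring, or a longer chain in place of the ring, would fare on this carbon.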